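Sulfonamide aryl swap from compound 3 to compound 4

The source may hold more compounds than are shown below. What is called first, only, known or untested is meant among the compounds shown, and "the series" means these compounds.

Measured so far in a functional assay on cells (leukaemia cell line, Homo sapiens) for inhibition, read by sulforhodamine B assay, with a stated time of 48 h; on this read-out lower numbers stand for stronger inhibition of growth and higher numbers for weaker inhibition of growth:
- compound 1 `O=S(=O)(Nc1ccc(Cl)c(F)c1)c1ccc(-c2cnc(C3CC3)o2)cc1`: 380 nM
- compound 2 `O=S(=O)(Nc1cccc(Cl)c1)c1ccc(-c2cnc(C3CC3)o2)cc1`: 477 nM
- compound 3 `O=S(=O)(Nc1ccc(F)cc1F)c1ccc(-c2cnc(C3CC3)o2)cc1`: 356 nM

Compound 3, at 356 nM, cannot be separated from the other two compounds, since every step among the three stays within the scatter. The next change is made on a sulfonamide nitrogen: compound 4 `O=S(=O)(Nc1cc(F)cc(Cl)c1)c1ccc(-c2cnc(C3CC3)o2)cc1` carries 3-chloro-5-fluorophenyl in place of 2,4-difluorophenyl (3-chloro-5-fluorophenyl in place of 2,4-difluorophenyl on a sulfonamide nitrogen).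

Going by the values given here, three measured steps bear on this change, all of them swaps of the aryl group at that same nitrogen: a 1.3-fold higher number from compound 1 to compound 2 (0.10 log units; within the scatter), a 1.1-fold lower number from compound 1 to compound 3 (0.03 log units; within the scatter) and a 1.3-fold lower number from compound 2 to compound 3 (0.13 log units; within the scatter). All three are small. Among the compounds with values here, the entering group holds one chlorine and one fluorine, as does the 4-chloro-3-fluorophenyl of compound 1 at 380 nM, but no measured compound carries this exact group. On these three compounds alone, no step beyond the scatter is expected in this assay, and no direction can be called with confidence. The expected step is a 1.1-fold higher number from compound 3 to compound 4 (0.05 log units; within the scatter). For compound 4 the estimated value is 400 nM, with an expected range from 220 nM to 720 nM.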

Compound 4, concentration for 50% growth inhibition: 1440 nM
Compound 4: middle estimate off by 3.6-fold (0.56 log units), on the low side, outside the stated range (above it).
By their numbers in this assay, from the lowest: compounds 3, 1 and 2 (each within the scatter of the next); then compound 4.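

In this assay the aryl group on the sulfonamide nitrogen can move the number beyond the scatter, which the first three compounds did not show: 3-chloro-5-fluorophenyl in place of 2,4-difluorophenyl gives a 4.0-fold higher number from compound 3 to compound 4 (0.61 log units; beyond the scatter). Which halogens the ring holds does not alone set the number, since 3-chloro-5-fluorophenyl and 4-chloro-3-fluorophenyl each hold one chlorine and one fluorine, and the swap between them still gives a 3.8-fold higher number from compound 1 to compound 4 (0.58 log units; beyond the scatter). Fluoro in place of hydrogen on an aromatic carbon of the 3-chlorophenyl group is enough on its own to give a 3.0-fold higher number from compound 2 to compound 4 (0.48 log units; beyond the scatter), and nothing at hand explains any of these steps.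

The compounds shown leave open whether a methoxy group or an amine on this phenyl ring would stay with compounds 1, 2 and 3 or move the number as far as compound 4 does. They also leave open whether a carboxylic acid on the ring would be tolerated in this assay, and whether 3-chloro-5-fluorophenyl gives a step of similar size when the cyclopropyl group of the shared core is replaced by a longer chain.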